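Swapping benzyl for pyridin-2-yl on compound 3

A few compounds are considered here, and "the series" means these few. Any claim that something is new, unique, unknown or untested is made for them only; others in the source may bear on it.

In a functional assay on the whole organism with Mus musculus as the target (a lower number here means that less compound is needed, a higher number that more compound is needed for the effect), compound 3 `C[C@@H](NCc1ccc(OCCc2ccccc2)cc1)C(N)=O` gives 24.9 mg/kg. That lies within the usual scatter of compound 2 `C[C@@H](NCc1ccc(Cc2ccccc2)cc1)C(N)=O` at 15.7 mg/kg, so these two cannot be told apart. Both need far less material than compound 1 `CNC(=O)[C@@H](CC(C)C)NCc1ccc(OCc2ccccc2)cc1` at 192 mg/kg.

The next compound to be tested, compound 4 `C[C@@H](NCc1ccc(OCc2ccccn2)cc1)C(N)=O`, changes one part of compound 3: pyridin-2-yl in place of benzyl on a saturated chain carbon bound to an oxygen on an aromatic ring. In words, this puts pyridin-2-yl in place of benzyl on a saturated chain carbon bound to an oxygen on an aromatic ring.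

For the measured compounds named here, no measured pair in this small set shows such an exchange, so any forecast in this assay is rough. The best guide is how close compound 2 at 15.7 mg/kg and compound 3 at 24.9 mg/kg lie, even though their structures differ. The expected change is a 1.2-fold higher number from compound 3 to compound 4 (0.08 log units; within the scatter), a slight move toward a higher number and none beyond the scatter. For compound 4, the estimated value is 30 mg/kg, with an expected range from 12 mg/kg to 75 mg/kg.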

Compound 4, dose for half-maximal effect: 172 mg/kg
Compound 4: middle estimate off by 5.7-fold (0.76 log units), on the low side, outside the stated range (above it).
By their numbers in this assay, from the lowest: compounds 2 and 3 (each within the scatter of the next); then compounds 4 and 1 (each within the scatter of the next).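

On a saturated chain carbon bound to an oxygen on an aromatic ring, pyridin-2-yl is not a quiet replacement for benzyl: in this assay the exchange brings a 6.9-fold higher number from compound 3 to compound 4 (0.84 log units; beyond the scatter), so much more compound is needed for the effect. The exchange alters two things at once, since benzyl has 7 heavy atoms, all carbon, while pyridin-2-yl has 6, including 1 nitrogen, and adds 1 hydrogen-bond acceptor, and this single step cannot separate the two. Nothing available here shows why the number rises.

Still open, as far as these compounds go, is whether the ring nitrogen or the shorter reach of the group matters more. A longer chain carrying pyridin-2-yl, or pyridin-3-yl or pyridin-4-yl at this place, would help to tell these apart.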